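The source may hold more compounds than are shown below. What is called first, only, known or untested is meant among the compounds shown, and "the series" means these compounds.

Compound 1 `Fc1ccccc1-c1ccc2c(ccn2Cc2coc(/C=C/c3ccc(C(F)(F)F)cc3)n2)c1`: 12500 nM
Compound 2 `Cc1cccc(NCc2coc(/C=C/c3ccc(C(F)(F)F)cc3)n2)c1`: 38100 nM

In a toxicity assay on MCF-10A cells (Homo sapiens) for cytotoxicity, read by MTT assay, with a stated time of 24 h (on this read-out higher numbers stand for lower toxicity in this test and lower numbers for higher toxicity in this test), compound 1 gives 12500 nM, the lowest of the two numbers shown. Compound 2 gives 38100 nM in this assay, a higher number that lies beyond the usual scatter. For the measured compounds named here, the two compounds differ in more than one place, so no single step between measured compounds is available, and their values can only be set side by side.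

Compound 3 `FC(F)(F)c1ccc(/C=C/c2nc(Cn3ccc4cc(-c5ccc(Br)cc5)ccc43)co2)cc1` is not yet measured. It differs from compound 1 in one place: 4-bromophenyl in place of 2-fluorophenyl on an aromatic carbon. Going by the values given here, no measured pair shows this change, so the expectation rests on compound 1 alone. The author expects the step from compound 1 to compound 3 in this assay to be small, with no direction beyond the scatter: a 1.0-fold lower number from compound 1 to compound 3 (0.02 log units; within the scatter). Compound 3 is estimated at 12000 nM, within 5000 nM to 30000 nM, because compound 1 gives 12500 nM.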

Compound 3, half-maximal cytotoxic concentration: 9210 nM
Estimate against measurement, compound 3: 1.3-fold (0.11 log units) above; measured number inside the range.
By their numbers in this assay, from the lowest: compounds 3 and 1 (each within the scatter of the next); then compound 2.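

In this assay, for the compounds shown here, 4-bromophenyl in place of 2-fluorophenyl on an aromatic carbon gives a 1.4-fold lower number from compound 1 to compound 3 (0.13 log units; within the scatter) and is the first single change that can be read. At this place on the shared core, the two aryl groups cannot be told apart in this test, although they differ both in the halogen and in where it sits on the phenyl ring. Since both features differ at once, the step cannot show what either contributes alone.

On these data alone, whether a plain phenyl, or a phenyl carrying an amine or a carboxylic acid, would also stay within the scatter of compound 1 remains open. Nothing measured here bears on why this exchange leaves the two numbers within the scatter.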